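The source may report more compounds than this note shows. Statements on the series, on what has been measured and on what is new or still open speak of the compounds shown alone.

In a functional assay on HT-29 cells (Homo sapiens) for antiproliferative activity, read by sulforhodamine B assay, with a stated time of 72 h (on this read-out lower numbers stand for stronger inhibition and higher numbers for weaker inhibition), compound 1 `O=C1CS/C(=N/Nc2nncc3ccccc23)N1c1ccccc1` gives 47 nM and compound 3 `COc1ccc(NC(=S)NNc2nncc3ccccc23)cc1` gives 20 nM while compound 2 `O=S(=O)(Nc1ncccn1)c1ccc(Nc2nncc3ccccc23)cc1` gives 29 nM as the middle of the three numbers, within the usual scatter of each of the other two. Compound 4 `NS(=O)(=O)c1ccc(Nc2nncc3ccccc23)cc1` has not yet been measured. Its structure departs from that of compound 2 in one place: hydrogen in place of pyrimidin-2-yl on a sulfonamide nitrogen. For the measured compounds named here, no measured pair shows this change on its own, so the data offer no direct guide to it. Going by the values given here, the expectation rests instead on the narrow spread of the measured compounds, whose quite different groups on the shared core run only from compound 3 at 20 nM to compound 1 at 47 nM in this assay so far. The expected step, a 1.4-fold higher number from compound 2 to compound 4 (0.14 log units; within the scatter) in this assay is small, toward a somewhat higher number, and it may well stay within the scatter. For compound 4 the estimated value is 40 nM with 12 nM as the lower and 130 nM as the upper end of the expected range.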

Compound 4, half-maximal inhibitory concentration: 12 nM
Compound 4: the middle estimate sits 3.3-fold (0.52 log units) above what was measured; the range from low to high includes it.
By their numbers in this assay, from the lowest: compounds 4, 3, 2 and 1 (each within the scatter of the next, the first and the last beyond it).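

In this assay, for the compounds shown here, replacing pyrimidin-2-yl with hydrogen on the sulfonamide nitrogen gives a 2.4-fold lower number from compound 2 to compound 4 (0.38 log units; beyond the scatter) and is the first change at a single place on the shared core that can be read. It shows that this nitrogen does not need the six-membered aromatic ring to keep its activity in these cells, since the number falls rather than rises when the ring leaves. The compounds shown offer no explanation for this fall.

From the compounds shown here alone, with only hydrogen and pyrimidin-2-yl seen on this nitrogen, it remains open whether any group placed there raises the number or whether this ring alone does. A methyl, an acetyl or a phenyl group on the same nitrogen would show whether the number climbs steadily or only with certain groups.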